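The compounds below may be only part of what the source reports. "The series", "measured", "known", "first", "only" and "open" are said of these compounds alone.

Working notes on the series, step from compound 2 to compound 3.

The series is followed in a functional assay on CHO cells for agonist activity at Alpha-1B adrenergic receptor (Homo sapiens), read by FLIPR and calcium flux; on this read-out higher numbers stand for an effect only at larger amounts of compound and lower numbers for an effect already at smaller amounts. Compound 1, `Cc1n[nH]cc1-c1cccc2c1CCC2c1ncc[nH]1`, gives 902 nM in this assay. Compound 2, `Cn1ccc(-c2cccc3c2CCC3c2ncc[nH]2)n1`, carries 1-methyl-1H-pyrazol-3-yl in place of 3-methyl-1H-pyrazol-4-yl on an aromatic carbon. In this assay compound 2 reaches only the limit of the measurement, > 10000 nM, so no number is known for it. Within the data shown here, the change is a step of an at least 11-fold higher number from compound 1 to compound 2 (1.04 log units; beyond the scatter), the only step measured so far, and it ends at the limit described by the limit of > 10000 nM in this assay, at which 1 of the 2 values shown sits.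

Compound 3, `c1cc(-c2ncco2)c2c(c1)C(c1ncc[nH]1)CC2`, is not yet measured. It differs from compound 2 as follows: 1,3-oxazol-2-yl in place of 1-methyl-1H-pyrazol-3-yl on an aromatic carbon. Among the measured compounds shown here, the one measured step runs into the limit, so it shows only that the shared core without the 3-methyl-1H-pyrazol-4-yl group of compound 1 is weak in this assay; it does not say how an oxazole compares to the methylated pyrazole. The expected step in this assay, a step that the limit leaves unreadable from compound 2 to compound 3, is therefore set near zero with wide uncertainty. For compound 3 the estimate in this assay is 12000 nM, with a range from 2000 nM to 60000 nM, and a limit-only result is judged more likely than not.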

Compound 3, half-maximal effective concentration: > 10000 nM
Compound 3 gave a limit, no number; the forecaster's own chance of this, stated with the estimate: 65%; the middle value is on the limit's open side.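

In this assay, 1,3-oxazol-2-yl in place of 3-methyl-1H-pyrazol-4-yl on the aromatic carbon gives an at least 11-fold higher number from compound 1 to compound 3 (1.04 log units; beyond the scatter), so the large change is no longer tied to the single replacement by 1-methyl-1H-pyrazol-3-yl. Of the three groups shown at this position, only the 3-methyl-1H-pyrazol-4-yl group yields a number, with compound 1 at 902 nM. The step between the two compounds that carry the other groups cannot be read, so 1,3-oxazol-2-yl and 1-methyl-1H-pyrazol-3-yl cannot be ordered, and the series now rests largely on a limit rather than on numbers: the limit of > 10000 nM in this assay, at which 2 of the 3 values shown sit.

The compounds shown do not separate the contribution of the methyl group in 3-methyl-1H-pyrazol-4-yl from that of the rest of this ring, and a 1H-pyrazol-4-yl group without the methyl group would address that directly. On these data alone, how an amine or a carboxylic acid at this position would read in this assay also stays open, as does whether any group here can give a lower number than compound 1.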